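The source may report more compounds than this note shows. Statements on the series, on what has been measured and on what is new or still open speak of the compounds shown alone.

In a physicochemical assay for solubility, using the shake flask method, in simulated intestinal fluid, measured as kinetic solubility, with a stated time of 2 h, at 25 degrees C, at pH 6.5 (on this read-out lower numbers stand for lower solubility and higher numbers for higher solubility), compound 1 `Cc1noc(-c2nc(C)c3c(c2N)C(=O)N(CC2CCNCC2)C3=O)n1` gives 160000 nM. Compound 2 `Cc1noc(-c2nc(C)c3c(c2N)C(=O)N(Cc2ccc(C(F)(F)F)cc2)C3=O)n1` gives < 5000 nM, which is a limit of the assay and not a number. Compound 3 `Cc1noc(-c2nc(C)c3c(c2N)C(=O)N(Cc2ccc(Br)cc2)C3=O)n1` gives < 5000 nM, also a limit and not a number. Compound 3 therefore stands at the limit of < 5000 nM in this assay, at which 2 of the 3 values shown sit.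

Compound 4 `Cc1noc(-c2nc(C)c3c(c2N)C(=O)N(Cc2cccc(F)c2)C3=O)n1` keeps the shared core and has 3-fluorophenyl in place of 4-bromophenyl on a saturated chain carbon bound to an amide-type nitrogen in a ring.

Two measured steps replace piperidin-4-yl with a substituted phenyl: an at least 32-fold lower number from compound 1 to compound 2 (1.50 log units; beyond the scatter) and an at least 32-fold lower number from compound 1 to compound 3 (1.50 log units; beyond the scatter). Both are large. The closest comparison, a step that the two limits leave unreadable from compound 2 to compound 3, swaps one phenyl substituent for another, as the new change does. Compound 4 still has a substituted phenyl at this place, so it is expected to stay near the limit, with no large rise towards compound 1.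

The expected change is a step that the limit leaves unreadable from compound 3 to compound 4, and no step beyond the scatter is expected. Compound 4 is estimated at 4000 nM, with an expected range of 1500 nM to 12000 nM.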

Compound 4, solubility: < 5000 nM
Compound 4 ended at the assay's limit; the forecaster's own chance of this, stated with the estimate: 65%; the middle value is on the limit's open side.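

In this assay, 3-fluorophenyl joins 4-bromophenyl and 4-(trifluoromethyl)phenyl on the saturated chain carbon bound to an amide-type nitrogen in a ring, and the result is again a limit of the assay, not a number: the limit of < 5000 nM in this assay, at which 3 of the 4 values shown sit.

Putting 3-fluorophenyl in place of piperidin-4-yl gives an at least 32-fold lower number from compound 1 to compound 4 (1.50 log units; beyond the scatter), so the large drop seen with compound 2 and compound 3 now extends to a third substituted phenyl, one with a different halogen at a different ring position. The steps among compound 2, compound 3 and compound 4 cannot be read, since all three values are limits.

As far as these compounds go, how far these three compounds lie beyond the limit remains open. Also open, from the compounds shown here alone, is whether a phenyl carrying an amine or a carboxylic acid at this place would come back off the limit towards compound 1.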